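Pyrazole Swap on Compound 2: Expected Shift in Lipophilicity

The source may report more compounds than this note shows. Statements on the series, on what has been measured and on what is new or still open speak of the compounds shown alone.

Three compounds of the series carry a measurement in a physicochemical assay for lipophilicity, using the shake flask method, at pH 7.4; a lower number here means a more polar compound, a higher number a more lipophilic compound. Compound 2 `CCCC(Oc1ccc(-n2cc(C#N)cn2)cc1)c1ccc(C(=O)NCCC(=O)O)cc1` gives 1.2 in this assay, the lowest of the three numbers. Its nearest neighbour is compound 3 `CCCC(Nc1ccc(-n2cc(C(F)(F)F)cn2)nc1)c1ccc(C(=O)NCCC(=O)O)cc1`, which in this assay gives 2.1, a gap beyond the usual scatter. Furthest from it is compound 1 `CCCC(Nc1cc(C)c(-n2cc(C(F)(F)F)cn2)c(C)c1)c1ccc(C(=O)NCCC(=O)O)cc1`, which in this assay gives 2.2, again a gap beyond the scatter. Compound 1 and compound 3 lie within the scatter of each other.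

Compound 4 `CCCC(Oc1ccc(-n2cc(C(F)(F)F)c(C)n2)cc1)c1ccc(C(=O)NCCC(=O)O)cc1` has not been measured in this assay. Compared with compound 2 the change is 3-methyl-4-(trifluoromethyl)-1H-pyrazol-1-yl in place of 4-cyano-1H-pyrazol-1-yl on an aromatic carbon. The group that leaves is the 4-cyano-1H-pyrazol-1-yl; the group that enters, 3-methyl-4-(trifluoromethyl)-1H-pyrazol-1-yl, sits on an aromatic carbon of a six-membered aromatic ring of carbon only. For the measured compounds named here, no measured pair in the set isolates this particular change, so the direction rests on the gap between the cyano compound 2 and the trifluoromethyl compounds 1 and 3.

The step from compound 2 to compound 4 is expected to be upward and beyond the scatter, at about a number 1.40 log units higher from compound 2 to compound 4 (beyond the scatter). Compound 4 is estimated at 2.6 in this assay, with a range from 2 to 3.2.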

Compound 4, distribution coefficient: 2.8
Estimate against measurement, compound 4: 0.20 log units below; low and high end bracket the measured number.
By their numbers in this assay, from the lowest: compound 2; then compounds 3 and 1 (each within the scatter of the next); then compound 4.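

In this assay, putting 3-methyl-4-(trifluoromethyl)-1H-pyrazol-1-yl in place of 4-cyano-1H-pyrazol-1-yl on the aromatic carbon para to a large group gives a step of a number 1.60 log units higher from compound 2 to compound 4 (beyond the scatter). For the compounds shown here, this is the first pair that differs in one place only, so the number at this position can now be read directly, without a comparison across compounds that also differ elsewhere. The compounds shown offer no measurement that accounts for the size of this step.

Going by these compounds alone, the single pair changes the nitrile for trifluoromethyl and adds the methyl in one move, so the share of the step belonging to each remains open; a 4-(trifluoromethyl)-1H-pyrazol-1-yl without the methyl, on the core of compound 2, would separate the two. Also open, going by these compounds, is how far the reading in this assay extends to other pyrazole substituents in this place, such as a methoxy group or a chlorine atom, and whether the same swap gives a step of similar size on the cores of compound 1 and compound 3.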